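Working notes: from compound 2 to compound 4

The source may hold more compounds than are shown below. What is called first, only, known or untested is meant among the compounds shown, and "the series" means these compounds.

Values so far in a functional assay on L6 cells (Rattus norvegicus) for inhibition, read by scintillation counting, with a stated time of 3 h; on this read-out higher numbers stand for weaker inhibition and lower numbers for stronger inhibition:
compound 1 `COc1ccc(CNC(=O)c2nc(-c3ccc(F)cc3)n(CC[C@@H](O)C[C@@H](O)CC(=O)O)c2C2CC2)cc1F` gives 890 nM
compound 2 `O=C(O)C[C@H](O)C[C@H](O)CCn1c(-c2ccc(F)cc2)nc(C(=O)NCc2cccc(F)c2)c1C1CC1` gives 444 nM
compound 3 `CN(C)S(=O)(=O)c1ccc(CNC(=O)c2nc(-c3ccc(F)cc3)n(CC[C@@H](O)C[C@@H](O)CC(=O)O)c2C2CC2)cc1` gives > 100000 nM as a limit of the assay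

For the measured compounds named here, compound 2 at 444 nM holds one of only two numeric values, and the other belongs to compound 1. The two do not separate: a 2.0-fold lower number from compound 1 to compound 2 (0.30 log units; within the scatter) is the measured step between them. Compound 3 sits at the limit of > 100000 nM in this assay, at which 1 of the 3 values shown sits, and gives no number.

Compound 4 `O=C(O)C[C@H](O)C[C@H](O)CCn1c(-c2ccc(F)cc2)nc(C(=O)NCc2ccccc2)c1C1CC1` differs from compound 2 at one spot: hydrogen in place of fluoro on an aromatic carbon. That is hydrogen in place of fluoro on an aromatic carbon, meta to a large group.

Going by the values given here, the closest precedent is compound 2 itself, where a 2.0-fold lower number from compound 1 to compound 2 (0.30 log units; within the scatter) also shows a single ring substituent giving way to hydrogen. The large steps, an at least 110-fold higher number from compound 1 to compound 3 (2.05 log units; beyond the scatter) and an at least 220-fold higher number from compound 2 to compound 3 (2.35 log units; beyond the scatter), end at a limit and exchange a much bigger piece, so they say little about this change.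

The expected step is a 1.1-fold higher number from compound 2 to compound 4 (0.05 log units; within the scatter), with no shift beyond the scatter expected in this assay in either direction.

Compound 4 is estimated at 500 nM, with an expected range from 200 nM to 1300 nM.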

Compound 4, half-maximal inhibitory concentration: 632 nM
Beside the measured number, compound 4's estimate is 1.3-fold (0.10 log units) below it; the range from low to high includes it.
By their numbers in this assay, from the lowest: compounds 2, 4 and 1 (each within the scatter of the next). At a limit, above all of these: compound 3.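

In this assay, compound 4 carries a plain phenyl on the benzylamino side, and neither fluoro nor methoxy on that ring separates it from its neighbours: a 1.4-fold higher number from compound 2 to compound 4 (0.15 log units; within the scatter) and a 1.4-fold lower number from compound 1 to compound 4 (0.15 log units; within the scatter) are both small steps that leave all three compounds together. For the compounds shown here, compound 4 also gives the first direct ring comparison with hydrogen as the reference, and an at least 150-fold lower number from compound 3 to compound 4 (2.19 log units; beyond the scatter) ties the large gap to dimethylsulfamoyl on that aromatic carbon, not to a requirement for a particular small ring substituent in compounds 1 and 2. Compound 3 still gives only a limit and not a number, so this gap has no measured upper end: the limit of > 100000 nM in this assay, at which 1 of the 4 values shown sits.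

The compounds shown leave open whether an amine, a carboxylic acid or a nitrile on the same ring would stay with compounds 1, 2 and 4 or fall towards compound 3. They also leave open whether a longer chain between the amide nitrogen and the phenyl would keep the values of this group, since every compound here retains the benzyl link.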